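The source may report more compounds than this note shows. Statements on the series, on what has been measured and on what is new or still open speak of the compounds shown alone.

Measured in a functional assay on MCF7 cells (Homo sapiens) for antiproliferative activity, read by sulforhodamine B assay, with a stated time of 48 h; on this read-out higher numbers stand for weaker inhibition and lower numbers for stronger inhibition:
- Compound 1 `CCN1CCN(c2ccc(S(=O)(=O)Oc3ccc(OC)cc3)cc2)C1=O`: > 100000 nM (a limit of the assay, not a number)
- Compound 2 `CCCCN1CCN(c2ccc(S(=O)(=O)Oc3cccc(Br)c3)cc2)C1=O`: 85 nM
- Compound 3 `CCCCN1CCN(c2ccc(S(=O)(=O)Oc3cc(Br)cc(Br)c3)cc2)C1=O`: 58 nM

Compound 3 gives 58 nM and stands within the scatter of compound 2, which gives 85 nM. Going by the values given here, these are the only two true numbers so far, and they mark strong inhibition in this assay.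

The next compound is compound 4 `CCCCN1CCN(c2ccc(S(=O)(=O)Oc3ccc(OC)cc3)cc2)C1=O`, where 4-methoxyphenyl takes the place of 3,5-dibromophenyl on an oxygen (4-methoxyphenyl in place of 3,5-dibromophenyl on an oxygen). Among the compounds with values here, the one measured step that bears on this change is a 1.5-fold lower number from compound 2 to compound 3 (0.17 log units; within the scatter), with bromo in place of hydrogen on an aromatic carbon. Within the data shown here, that step covers only a part of the change, and no measured step shows the full swap.

Compound 1 also carries 4-methoxyphenyl on that oxygen, and its result of > 100000 nM is a limit. Going by that result for compound 1 (the limit of > 100000 nM in this assay, at which 1 of the 3 values shown sits), a large step towards a higher number, well beyond the scatter, is expected in this assay. The expected size of the change is a 52-fold higher number from compound 3 to compound 4 (1.71 log units; beyond the scatter). For compound 4 the estimated value is 3000 nM, with an expected range from 300 nM to 50000 nM.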

Compound 4, half-maximal inhibitory concentration: 2500 nM
Estimate against measurement, compound 4: 1.2-fold (0.08 log units) above, and the stated range covers the measured number.
By their numbers in this assay, from the lowest: compounds 3 and 2 (each within the scatter of the next); then compound 4. At a limit, above all of these: compound 1.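

In this assay, the group on the oxygen bound to the sulfonyl sulfur now shows its weight on its own, with the rest of the structure held fixed: 4-methoxyphenyl in place of 3,5-dibromophenyl gives a 43-fold higher number from compound 3 to compound 4 (1.63 log units; beyond the scatter), and 4-methoxyphenyl in place of 3-bromophenyl gives a 29-fold higher number from compound 2 to compound 4 (1.47 log units; beyond the scatter). Compound 1 gives > 100000 nM, which is a limit of the assay and not a number, and it stands alone there: the limit of > 100000 nM in this assay, at which 1 of the 4 values shown sits. With 4-methoxyphenyl kept in place, the chain on the amide-type nitrogen in the ring also proves to matter, as going from the ethyl chain to the butyl chain gives an at least 40-fold lower number from compound 1 to compound 4 (1.60 log units; beyond the scatter), so 4-methoxyphenyl alone does not push a compound to the limit.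

The swap removes bromo and adds methoxy at once, so a plain phenyl or a 4-bromophenyl on that oxygen would be needed to tell the two apart. Only ethyl and butyl chains appear here, which leaves open how a hexyl chain, or a chain ending in an amine, would behave.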